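This account rests on a few compounds, and the source may have more. Where it says the series, first, only, none or still open, it means among the compounds named here.

Three compounds were tested in a functional assay on NCI-H727 cells (Homo sapiens) for cytotoxicity, with a stated time of 48 h; a lower number here means a stronger inhibitor, a higher number a weaker inhibitor. Compound 1 `COc1cc(O)c(C(=O)/C=C/c2ccc(F)cc2)c(OC)c1` gives > 20000 nM, which is a limit of the assay and not a number. Compound 2 `COc1cc(OC)c(C(=O)/C=C/c2ccccc2)c(OC)c1` gives 11400 nM, and compound 3 `COc1cc(O)c(C(=O)/C=C/c2ccccc2OC)c(OC)c1` gives 11000 nM; these two values lie within the scatter of each other. Compound 4 `COc1cc(OC)c(C(=O)/C=C/c2ccc(Br)cc2)c(OC)c1` has not yet been measured. It differs from compound 2 by bromo in place of hydrogen on an aromatic carbon, para to a large group, turning phenyl into 4-bromophenyl: bromo in place of hydrogen on an aromatic carbon. Among the measured compounds shown here, no measured step in this set shows this change, so no shift beyond the scatter is expected. The expected step is a 1.3-fold lower number from compound 2 to compound 4 (0.10 log units; within the scatter). The estimate for compound 4 is 9000 nM, with an expected range from 3500 nM to 20000 nM.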

Compound 4, half-maximal inhibitory concentration: 11300 nM
Estimate against measurement, compound 4: 1.3-fold (0.10 log units) below, within the range that was stated.
By their numbers in this assay, from the lowest: compounds 3, 4 and 2 (each within the scatter of the next). At a limit, above all of these: compound 1.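

Bromo in place of hydrogen on an aromatic carbon, para to a large group, gives the only step that can be read in this set (a 1.0-fold lower number from compound 2 to compound 4 (0.00 log units; within the scatter)), so turning phenyl into 4-bromophenyl here leaves the number within the scatter. Compound 1 alone remains at a limit, which is not a number: the limit of > 20000 nM in this assay, at which 1 of the 4 values shown sits. Still open, as far as these compounds go, is whether an amine, a carboxylic acid or a longer chain at this place would move the number beyond the scatter. This single step also cannot say whether bromo would do the same on the core of compound 1.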